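The compounds below may be only part of what the source reports. "The series", "measured", "known", "first", "only" and "open" are said of these compounds alone.

Measured in a functional assay on SNB-19 cells (Homo sapiens) for inhibition, read by MTT assay, with a stated time of 7 days; a lower number here means a stronger inhibitor of growth, a higher number a weaker inhibitor of growth:
- compound 1 `C[Si](C)(C)CCOCn1nnc2c(C(N)=O)ncn2c1=O` gives 29900 nM
- compound 2 `COc1ccc(Cn2nnc3c(C(N)=O)ncn3c2=O)cc1OC` gives > 50000 nM (a limit of the assay, not a number)

Among the measured compounds shown here, compound 1 holds the only actual number so far, since the other reading is a limit. Compound 3 `Cc1cc(Cn2nnc3c(C(N)=O)ncn3c2=O)on1` has not yet been measured. It keeps the core of compound 1 and differs on a saturated chain carbon bound to an aromatic nitrogen: a group of 6 heavy atoms (4 carbon, 1 nitrogen, 1 oxygen; one five-membered aromatic ring with 2 hetero atoms) in place of a group of 7 heavy atoms (5 carbon, 1 oxygen, 1 silicon; no ring), on a saturated chain carbon bound to an aromatic nitrogen. The group entering is 3-methyl-1,2-oxazol-5-yl. For the measured compounds named here, no measured pair differs in one place, so the size of this change has no direct precedent. The expectation rests on compound 1 with its 29900 nM as the sole anchor. The estimated step is a 1.3-fold higher number from compound 1 to compound 3 (0.10 log units; within the scatter), with none beyond the scatter expected. A reading that is only a limit is also expected to be quite possible. For compound 3 the estimated value is 38000 nM, with an expected range from 15000 nM to 50000 nM.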

Compound 3, concentration for 50% growth inhibition: > 50000 nM
Compound 3: no number, only a limit; the forecaster's own chance of this, stated with the estimate: 40%; middle value at least 1.3-fold (0.11 log units) away from the limit.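

In this assay, among the compounds shown here, the one change at this saturated chain carbon bound to an aromatic nitrogen, 3-methyl-1,2-oxazol-5-yl in place of the silicon-bearing chain, gives an at least 1.6-fold higher number from compound 1 to compound 3 (0.22 log units; that floor lies within the scatter). Compound 3 gives > 50000 nM, which is a limit of the assay and not a number. This aromatic ring therefore brings no gain over compound 1 at this position, and the full size of the step stays unread because the reading ends at a limit: the limit of > 50000 nM in this assay, at which 2 of the 3 values shown sit.

Compound 1 remains the only numerical anchor in the series, so the compounds shown give no group on this carbon that lowers the number. Going by these compounds, whether a plain longer alkyl chain, a chain ending in an amine or one ending in a carboxylic acid would do so remains open.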